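The source may hold more compounds than are shown below. What is called first, only, known or untested is meant among the compounds shown, and "the series" means these compounds.

Of the compounds shown here, three have been tested in a functional assay on B16 cells (Mus musculus) for inhibition; a lower number here means a stronger inhibitor, a higher number a weaker inhibitor. Compound 1 `CC(C)CN(CC(=O)N(CC(C)C)NC(=O)OCc1ccccc1)NC(=O)CBr` gives 3300 nM, compound 2 `CC(C)CN(CC(=O)NN(Cc1ccccc1)c1cnccn1)NC(=O)CBr` gives 14800 nM, and compound 3 `CC(C)CN(NC(=O)OCc1ccccc1)C(=O)CN(Cc1ccccc1)NC(=O)Cc1cccc(Br)c1` gives 15800 nM. Compound 3 and compound 2 lie within the usual scatter of each other, so these two results cannot be told apart. Compound 1 has a lower number than compound 3, and that gap is beyond the scatter, so compound 3 is the weaker inhibitor of that pair.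

Compound 4 `CC(C)CN(NC(=O)OCc1ccccc1)C(=O)CN(Cc1ccccc1)/N=C/c1ccccc1B(O)O` keeps most of compound 3 and changes one group on an amine nitrogen: a group of 11 heavy atoms (7 carbon, 1 boron, 1 nitrogen, 2 oxygen; one six-membered aromatic ring of carbon only) in place of a group of 11 heavy atoms (8 carbon, 1 nitrogen, 1 oxygen, 1 bromine; one six-membered aromatic ring of carbon only), on an amine nitrogen. The new group has boron and no bromine, and both groups hold one six-membered aromatic ring of carbon only. Among the compounds with values here, no two measured compounds differ in just one place, so the data give no direct guide to the size of this change. The expectation therefore starts from compound 3 at 15800 nM and allows for no shift beyond the scatter, with a slight lean towards a lower number. The expected step is a 1.6-fold lower number from compound 3 to compound 4 (0.20 log units; within the scatter). For compound 4 the estimated value in this assay is 10000 nM, with an expected range from 3000 nM to 33000 nM.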

Compound 4, half-maximal inhibitory concentration: 45100 nM
Beside the measured number, compound 4's estimate is 4.5-fold (0.65 log units) below it, and the stated range ends below it.
By their numbers in this assay, from the lowest: compound 1; then compounds 2 and 3 (each within the scatter of the next); then compound 4.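

In this assay, replacing the group with bromine on this amine nitrogen by the group with boron gives a 2.9-fold higher number from compound 3 to compound 4 (0.46 log units; beyond the scatter) and is the only direct reading of a single change among these compounds, pointing towards weaker inhibition. Both groups hold 11 heavy atoms and one six-membered aromatic ring of carbon only, so this position responds to a change that leaves those counts alike. The groups differ in their atoms, with 1 boron and 2 oxygen in place of 1 bromine and 1 oxygen, and in carrying 2 hydrogen-bond donors and 3 hydrogen-bond acceptors instead of 1 of each, but no measurement shown here explains the step.

This single swap alters several features at once, so the compounds shown cannot separate the gain of boron from the loss of bromine or from the other differences between the two groups. A group with a carboxylic acid or a chlorine on the aromatic ring, attached to this same amine nitrogen, could help to pull those features apart.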